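The source may hold more compounds than are shown below. What is called first, only, known or untested is meant among the compounds shown, and "the series" means these compounds.

Measured compounds:
compound 1, `CC(C)(C)c1ccc(C(=O)N2CCC3(CC2)C(=O)N(CC(=O)N2CCCC(C(N)=O)C2)CN3c2ccccc2)cc1`, 16900 nM
compound 2, `CC(C)(C)OC(=O)NCNC(=O)CN1CN(c2ccccc2)C2(CCN(C(=O)c3ccc(C4CCCCC4)cc3)CC2)C1=O`, 1700 nM
compound 3, `NCCNC(=O)CN1CN(c2ccccc2)C2(CCN(C(=O)c3ccc(C4CCCCC4)cc3)CC2)C1=O`, 3800 nM

In an assay on HEK293 cells for displacement of a labelled ligand from NPC1-like intracellular cholesterol transporter 1 (Homo sapiens) (a higher number here means a weaker inhibitor, a lower number a stronger inhibitor), compound 1 gives 16900 nM, the highest of the three numbers; compound 3 sits below it, and compound 2 sits lowest, both differences lying beyond the scatter. The unmeasured compound 4, `CC1CCCN(C(=O)CN2CN(c3ccccc3)C3(CCN(C(=O)c4ccc(C(C)(C)C)cc4)CC3)C2=O)C1`, keeps the core of compound 1 and differs from it in one place: methyl in place of carbamoyl on a saturated ring carbon.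

The only measured step among these compounds, a 2.2-fold higher number from compound 2 to compound 3 (0.35 log units; beyond the scatter), concerns a different part of the molecule and a different pair of groups, so it does not speak directly to the change from compound 1 to compound 4. What the numbers of compound 2 and compound 3 do show is that altering the group on the amide side chain moves this assay by a modest amount rather than a large one. Among the compounds with values here, no measured pair tells whether exchanging carbamoyl for methyl on the saturated ring carbon helps or hurts. Compound 4 is therefore expected to land near compound 1, with a step of a 1.4-fold lower number from compound 1 to compound 4 (0.15 log units; within the scatter) that could fall on either side of the scatter. The estimate for compound 4 in this assay is 12000 nM, between 4000 nM and 40000 nM.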

Compound 4, half-maximal inhibitory concentration: 12000 nM
For compound 4 middle estimate and measured number coincide at the digits printed; low and high end bracket the measured number.
By their numbers in this assay, from the lowest: compound 2; then compound 3; then compounds 4 and 1 (each within the scatter of the next).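

In this assay, within the data shown here, the step at this position, a 1.4-fold lower number from compound 1 to compound 4 (0.15 log units; within the scatter), gives the first direct reading of a change on this saturated ring carbon, two ring bonds from the ring nitrogen and two ring bonds from the ring atom that bears a large group. Going from 3-carbamoylpiperidin-1-yl to 3-methylpiperidin-1-yl takes away the hydrogen-bond donor and acceptor that carbamoyl carries, and methyl brings neither, yet the assay does not separate the two compounds, so for this pair the carbamoyl group can be exchanged without a change that stands out from the scatter. Nothing measured here explains why the exchange leaves the reading within the scatter.

Still open, going by these compounds, is whether any other group on this ring carbon, such as an amine, a carboxylic acid, a hydroxyl or a longer chain like ethyl or propyl, would move the number beyond the scatter, or whether a plain piperidin-1-yl with no group on that carbon would read the same. On these data alone, it also remains open whether the same exchange of carbamoyl for methyl would read alike on a compound carrying cyclohexyl in place of tert-butyl on the benzoyl group.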